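The source may hold more compounds than are shown below. What is called first, only, known or untested is meant among the compounds shown, and "the series" means these compounds.

Working notes on the series. In a functional assay on LNCaP cells (Homo sapiens) for inhibition, read by WST assay, with a stated time of 48 h (on this read-out higher numbers stand for weaker inhibition of growth and lower numbers for stronger inhibition of growth), compound 1 `C=C(C)C(=O)N(Cc1cccc(Br)c1)C(=O)/C=C/c1cc(OC)c(OC)c(OC)c1` gives 10000 nM. Compound 3 `C=C(C)C(=O)N(Cc1ccccc1C)C(=O)/C=C/c1cc(OC)c(OC)c(OC)c1` gives 10000 nM, level with compound 1 at the digits reported. Compound 2 `C=C(C)C(=O)N(C)C(=O)/C=C/c1cc(OC)c(OC)c(OC)c1` reads > 10000 nM, which is a limit and not a number.

Compound 4 `C=C(C)C(=O)NC(=O)/C=C/c1cc(OC)c(OC)c(OC)c1` has hydrogen in place of 3-bromobenzyl on an amide-type nitrogen.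

Among the compounds with values here, three measured steps bear on this change. The step of no change at the digits printed from compound 1 to compound 3 (within the scatter) exchanges one aromatic ring for another on the same saturated chain carbon and stays within the scatter. The steps of a number no lower from compound 1 to compound 2 (the limit leaves the size open) and a number no higher from compound 2 to compound 3 (the limit leaves the size open) remove or restore such a ring, but their size cannot be read. Within the data shown here, no measured step in this assay therefore shows a change beyond the scatter. Compound 2 is the closest analogue, and the direction of a number no lower from compound 1 to compound 2 (the limit leaves the size open) points to a slightly higher number, if any change occurs.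

The expected step is small: a 1.2-fold higher number from compound 1 to compound 4 (0.08 log units; within the scatter).

For compound 4 the estimate is 12000 nM, with an expected range of 5000 nM to 25000 nM.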

Compound 4, concentration for 50% growth inhibition: 10000 nM
Estimate against measurement, compound 4: 1.2-fold (0.08 log units) above; the measured number falls inside the stated range.
By their numbers in this assay, from the lowest: compounds 1, 3 and 4 (each within the scatter of the next).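

In this assay, removing the benzyl group from the amide-type nitrogen altogether gives no change at the digits printed from compound 1 to compound 4 (within the scatter), and likewise no change at the digits printed from compound 3 to compound 4 (within the scatter). The earlier readable step only exchanged one aromatic ring for another, whereas these two steps remove the ring entirely, so neither 3-bromobenzyl nor 2-methylbenzyl on this nitrogen shows any gain over the amide hydrogen. Compound 2 reads > 10000 nM, which is a limit, so the steps that involve it cannot be read: the limit of > 10000 nM in this assay, at which 1 of the 4 values shown sits. Hydrogen in place of methyl on this nitrogen gives a number no higher from compound 2 to compound 4 (the limit leaves the size open).

No step among the compounds shown lies beyond the scatter, so nothing here marks this nitrogen as a place where the number moves. Open, from the compounds shown here alone, is how a longer chain ending in an amine, or a benzyl group carrying a carboxylic acid, would read at this position.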